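Swapping an aminophenyl for a pyridyl on the hydrazone core

A few compounds are considered here, and "the series" means these few. Any claim that something is new, unique, unknown or untested is made for them only; others in the source may bear on it.

Compound 1 `Nc1ccc(C(=O)NN=C(c2ccccn2)c2ccccn2)cc1` is examined in an ADME assay on cells (Homo sapiens) for antiproliferative activity, read by MTT assay (on this read-out higher numbers stand for weaker inhibition and lower numbers for stronger inhibition), where compound 1 gives 7640 nM. That places it second highest of three numbers: compound 2 `C/C(=N\NC(=O)c1ccc(O)cc1)c1cnccn1` gives 16800 nM, and compound 3 `O=C(NN=C(c1ccccn1)c1ccccn1)c1ccc(C(F)(F)F)cc1` gives 240 nM. Going by the values given here, the one single-point step seen so far, a 32-fold lower number from compound 1 to compound 3 (1.50 log units; beyond the scatter), shows that changing the amino-bearing ring of compound 1 can move the result a great deal. Compound 4 `O=C(NN=C(c1ccccn1)c1ccccn1)c1ccncc1` differs from compound 1 in one place: pyridin-4-yl in place of 4-aminophenyl on a carbonyl carbon. Among the compounds with values here, no measured step covers this exact change, so the expectation rests loosely on the direction seen from compound 1 to compound 3. For compound 4 a modest lowering is estimated, a 2.5-fold lower number from compound 1 to compound 4 (0.41 log units; beyond the scatter), giving an expected value of 3000 nM, within a range from 800 nM to 12000 nM.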

Compound 4, half-maximal inhibitory concentration: 830 nM
For compound 4 the middle estimate is 3.6-fold (0.56 log units) above the measured one, within the range that was stated.
By their numbers in this assay, from the lowest: compound 3; then compound 4; then compound 1; then compound 2.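

The step of a 9.2-fold lower number from compound 1 to compound 4 (0.96 log units; beyond the scatter) shows that the number also falls when pyridin-4-yl, a ring with a nitrogen inside it, replaces 4-aminophenyl on the carbonyl carbon. A lower number here therefore does not require trifluoromethyl, although compound 4 at 830 nM remains above compound 3 at 240 nM. No available evidence explains this fall. Still open, going by these compounds, is how the number would respond if a carboxylic acid or a methoxy group replaced the amino group on the aromatic ring of compound 1.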